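Adding a Methoxy Group to a Benzothiazole Amide Series

A few compounds are considered here, and "the series" means these few. Any claim that something is new, unique, unknown or untested is made for them only; others in the source may bear on it.

In a functional assay on HeLa cells (Homo sapiens) for cytotoxicity, read by MTT assay, with a stated time of 48 h (a higher number here means a weaker inhibitor, a lower number a stronger inhibitor), the measured compounds stand as follows:

Compound 1, `COc1ccc(-c2cc(C(=O)Nc3nc4ccc(Cl)cc4s3)nc3cc(-c4ccccc4)nn23)cc1OC`, gives 9120 nM.
Compound 2, `COc1cc(-c2cc(C(=O)Nc3nc4ccc(Cl)cc4s3)nc3cc(-c4ccccc4)nn23)cc(OC)c1OC`, gives 22400 nM.
Compound 3, `COc1ccc(-c2cc(C(=O)Nc3nc4ccc(OC)cc4s3)nc3cc(-c4ccccc4)nn23)cc1`, gives 24500 nM.

Compound 1 and compound 2 differ in one place: methoxy in place of hydrogen on an aromatic carbon. That change brought a 2.5-fold higher number from compound 1 to compound 2 (0.39 log units; beyond the scatter). Compound 3 and compound 1 differ in more than one place, and the difference between the two cores is not broken down here; in this assay compound 3 has the highest of the three numbers, with compound 2 close to it within the scatter and compound 1 further away beyond it.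

Compound 4, `COc1ccc2nc(NC(=O)c3cc(-c4ccc(OC)c(OC)c4)n4nc(-c5ccccc5)cc4n3)sc2c1`, has not yet been measured. It is related to compound 3 by methoxy in place of hydrogen on an aromatic carbon. This is the same kind of change as that from compound 1 to compound 2, but the surroundings differ: in compound 2 the entering methoxy is also meta to a methoxy group, whereas in compound 4 it is not. Among the measured compounds shown here, with only one such step seen, the expectation for compound 4 rests on compound 1 and compound 2, whose step was a 2.5-fold higher number from compound 1 to compound 2 (0.39 log units; beyond the scatter), so a step of similar size is expected, a 1.8-fold higher number from compound 3 to compound 4 (0.26 log units; within the scatter). Compound 4 is therefore estimated at 45000 nM in this assay, with a range from 18000 nM to 110000 nM; since compound 3 already sits high, a reported limit rather than a number cannot be ruled out.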

Compound 4, half-maximal inhibitory concentration: 11000 nM
Compound 4: the middle estimate sits 4.1-fold (0.61 log units) above what was measured; measured number outside the range, below it.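

In this assay, the methoxy that turns 4-methoxyphenyl into 3,4-dimethoxyphenyl brought a 2.2-fold lower number from compound 3 to compound 4 (0.35 log units; beyond the scatter), while adding a methoxy on the core of compound 1 had raised the number, and the two steps do not agree: the same change on two cores in this assay, a 2.5-fold higher number (0.39 log units; beyond the scatter) from compound 1 to compound 2 and a 2.2-fold lower number (0.35 log units; beyond the scatter) from compound 3 to compound 4, 5.5-fold (0.74 log units) apart, beyond the scatter of two such steps Within these two pairs, then, the change did not carry from one core to the other, not even in direction, although the entering methoxy also stands in different surroundings in the two pairs, and two pairs show neither which difference between the cores matters nor how the change would behave on any other core. Replacing chloro with methoxy on an aromatic carbon gave a 1.2-fold higher number from compound 1 to compound 4 (0.08 log units; within the scatter), a step within the scatter, but this single pair does not show that the two groups can be exchanged on other cores or with other aryl groups.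

The compounds shown leave open which way the methoxy step would go on a third core, and so whether either of the two results is the more typical one. They also leave open what a hydroxy group, a fluoro group or an amine would do when placed on the same aromatic carbon as the entering methoxy.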